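A few compounds are considered here, and "the series" means these few. Any claim that something is new, unique, unknown or untested is made for them only; others in the source may bear on it.

Of the compounds shown here, three from this series have been tested in an ADME assay on KB cells (Homo sapiens) for cytotoxicity (on this read-out higher numbers stand for an effect only at larger amounts of compound and lower numbers for an effect already at smaller amounts), and a fourth awaits testing. Compound 1 `CCOC(=O)N1[C@@H]2C=C[C@@](OC)(C(=O)c3c2cc(OC)c(OC)c3OCc2ccc(OC)cc2)N1C(=O)OCC` gives 63.1 ug/mL in this assay. Compound 3 `CCCCOc1c(OC)c(OC)cc2c1C(=O)[C@]1(OC)C=C[C@H]2N(C(=O)OCC)N1C(=O)OCC` differs from compound 1 in a single spot, namely (propyl in place of 4-methoxyphenyl on a saturated chain carbon bound to an oxygen on an aromatic ring), and in this assay compound 3 gives 76 ug/mL. The resulting step, a 1.2-fold higher number from compound 1 to compound 3 (0.08 log units; within the scatter), is a small one, and the data mark it as lying within the usual scatter of repeated measurements.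

Compound 2 `COc1ccc(COc2c(OC)c(OC)cc3c2C(=O)[C@]2(OC)C=C[C@H]3N(C(=O)OCC(C)C)N2C(=O)OCC(C)C)cc1` carries the same 4-methoxyphenyl group as compound 1 but rests on a different core; the difference between the two cores is not broken down here. In this assay compound 2 gives 47.9 ug/mL, a value that sits within the usual scatter of the value of compound 1.

Compound 4 `CCCCOc1c(OC)c(OC)cc2c1C(=O)[C@]1(OC)C=C[C@H]2N(C(=O)OCC(C)C)N1C(=O)OCC(C)C` stands to compound 2 exactly as compound 3 stands to compound 1: the change is propyl in place of 4-methoxyphenyl on a saturated chain carbon bound to an oxygen on an aromatic ring, made at the same place, so it is the same change seen a second time. The expected step is a 1.2-fold higher number from compound 2 to compound 4 (0.08 log units; within the scatter), set beside the measured 1.2-fold higher number from compound 1 to compound 3 (0.08 log units; within the scatter), because the earlier step of a 1.2-fold higher number from compound 1 to compound 3 (0.08 log units; within the scatter) barely moved the number. On that basis compound 4 is expected to give about 57 ug/mL in this assay, with a likely range from 30 ug/mL to 110 ug/mL, a range that reflects the scatter of the assay rather than any expected shift.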

Compound 4, concentration for half-maximal effect: 22.1 ug/mL
Estimate against measurement, compound 4: 2.6-fold (0.41 log units) above, outside the stated range (below it).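

In this assay, replacing 4-methoxyphenyl with propyl on the core of compound 2 gives a 2.2-fold lower number from compound 2 to compound 4 (0.34 log units; beyond the scatter), a modest step, while the same change on the core of compound 1 gives a 1.2-fold higher number from compound 1 to compound 3 (0.08 log units; within the scatter). Taken one at a time, these steps seem to tell different stories, since only the first lies beyond the scatter, but the comparison that matters is the gap between them, and that gap is no larger than two such steps can show from scatter alone: the same change on two cores in this assay, a 1.2-fold higher number (0.08 log units; within the scatter) from compound 1 to compound 3 and a 2.2-fold lower number (0.34 log units; beyond the scatter) from compound 2 to compound 4, 2.6-fold (0.42 log units) apart, within the scatter of two such steps. This shows that the change cannot be said to behave differently on the two cores, but it does not show that the change carries over unaltered, as a single pair on each core cannot settle the question either way, and the lower number for compound 4 remains a result for that core alone.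

The compounds shown leave open whether a third core would give a step like either of these, and how the number would respond to a longer chain such as hexyl at the same place. They also leave open what a chain carrying an amine or a carboxylic acid would do there, on either core.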